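Benzoyl for isopropyl: a cytotoxicity limit under test

The source may report more compounds than this note shows. Statements on the series, on what has been measured and on what is new or still open speak of the compounds shown alone.

Compound 1 `CCc1ccc(CN[C@H]2CC(C(=O)O)=C[C@@H](OC(CC)CC)[C@@H]2NC(C)=O)cc1` in an ADME assay on cells (Fibroblast, Gallus gallus) for cytotoxicity, read by CCK-8 assay, with a stated time of 48 h (a higher number here means that more compound is tolerated, a lower number that less compound is tolerated), is reported only as a limit: compound 1 gives > 200000 nM.
Compound 2 `CCC(CC)O[C@@H]1C=C(C(=O)O)C[C@H](NCc2ccc(C(C)C)cc2)[C@H]1NC(C)=O` is likewise reported only as a limit: compound 2 gives > 200000 nM.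
Compound 3 `CCC(CC)O[C@@H]1C=C(C(=O)O)C[C@H](NCc2ccc(-c3ccc(SC)cc3)cc2)[C@H]1NC(C)=O` is also reported only as a limit: compound 3 gives > 200000 nM.

Compound 2 therefore stands at the top of the measured range, sharing its limit with both other compounds. The account follows compound 2 to compound 4 `CCC(CC)O[C@@H]1C=C(C(=O)O)C[C@H](NCc2ccc(C(=O)c3ccccc3)cc2)[C@H]1NC(C)=O`, where the change is benzoyl in place of isopropyl on an aromatic carbon. Going by the values given here, two measured steps touch the same aromatic carbon: a step that the two limits leave unreadable from compound 1 to compound 2 and a step that the two limits leave unreadable from compound 2 to compound 3, and neither is readable, because of the limit of > 200000 nM in this assay, at which 3 of the 3 values shown sit. A replacement of a small alkyl group by a larger aromatic one at this carbon, as from compound 2 to compound 3, gave no readable movement. No step beyond the scatter can thus be expected in this assay; the likeliest outcome is another limit. Compound 4 is estimated at 250000 nM, in the range 80000 nM to 800000 nM. The expected step is a step that the limit leaves unreadable from compound 2 to compound 4.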

Compound 4, half-maximal cytotoxic concentration: > 200000 nM
Compound 4 gave a limit, no number; the forecaster's own chance of this, stated with the estimate: 85%; the middle value is on the limit's open side.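

No step can be read from compound 4 to compound 1, compound 2 or compound 3 in this assay, because each of the four is reported only as the same limit: the limit of > 200000 nM in this assay, at which 4 of the 4 values shown sit.

The compounds shown leave open what half-maximal cytotoxic concentration any of the four actually has.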